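Swapping a chloro for a methoxy on the benzylamine arm

The source may report more compounds than this note shows. Statements on the series, on what has been measured and on what is new or still open speak of the compounds shown alone.

Compound 1 `Nc1nc(NCc2ccc(Cl)cc2)nc(-c2ccccc2CO)n1`: 5.22
Compound 2 `Nc1nc(NCc2cccc(C(F)(F)F)c2)nc(-c2ccccc2CO)n1`: 5.11

In a functional assay on cells for positive allosteric modulation of G-protein coupled receptor 68 (Homo sapiens), read by a luciferase reporter and cAMP accumulation, with a stated time of 30 min, at pH 6.8 and pH 8.3, in the presence of a further agent that is not named here (a higher number here means a more potent compound, by a factor of ten per unit of this negative logarithm, a lower number a less potent compound), compound 1 gives 5.22 and compound 2 gives 5.11; the two numbers sit within the scatter of each other, so neither can be set above the other. Compound 3 `COc1ccc(CNc2nc(N)nc(-c3ccccc3CO)n2)cc1` is not yet measured. It differs from compound 1 in one place: methoxy in place of chloro on an aromatic carbon. Among the compounds with values here, no comparable step has been measured here, so the size of the change is open. The expectation is a step of no more than the scatter, a number 0.12 log units lower from compound 1 to compound 3 (within the scatter), with compound 3 estimated at 5.1, between 4.7 and 5.5.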

Compound 3, negative logarithm of the antagonist equilibrium constant: 3.34
The estimate for compound 3 lay 1.76 log units above the measured number; the whole stated range lies above it.
By their numbers in this assay, from the lowest: compound 3; then compounds 2 and 1 (each within the scatter of the next).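

Methoxy in place of chloro on this aromatic carbon gives a number 1.88 log units lower from compound 1 to compound 3 (beyond the scatter) in the same read-out, the first single change here that can be sized. It shows that this position on the benzylamine arm is far from indifferent to which small group it carries, even with the rest of the molecule unchanged. Nothing available explains the fall.

Going by these compounds, whether an amine, a hydroxyl or a longer chain such as ethoxy at this carbon would stay near compound 1 or fall towards compound 3 remains open. So does whether this swap would cost as much at another carbon of the ring.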